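Series notes: oxindole-indole pair, swap on the oxindole

A few compounds are considered here, and "the series" means these few. Any claim that something is new, unique, unknown or untested is made for them only; others in the source may bear on it.

Of the compounds shown here, two have been measured in a functional assay on cells (Cancer cell lines, Homo sapiens) for cytotoxicity, with a stated time of 48 h; a lower number here means a stronger inhibitor of growth, a higher number a weaker inhibitor of growth. Compound 1 `COc1cc2c(/C=C3/C(=O)Nc4ccc(O)cc43)c(Cl)n(Cc3cc(OC)c(OC)c(OC)c3)c2cc1C` gives 49000 nM. Compound 2 `O=C1/C(=C/c2c(Cl)[nH]c3ccccc23)c2ccccc2N1Cc1ccccc1` is a simpler member without the methoxy-bearing substituents of compound 1. In this assay compound 2 gives 79400 nM. The two numbers lie within the usual scatter of each other, so neither can be called the stronger growth inhibitor on this evidence.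

Compound 3 `COc1cc2c(/C=C3/C(=O)Nc4cccc(Cl)c43)c(Cl)n(Cc3cc(OC)c(OC)c(OC)c3)c2cc1C` has not yet been measured in this assay. It differs from compound 1 in one place: a group of 12 heavy atoms (9 carbon, 1 nitrogen, 1 oxygen, 1 chlorine; one five-membered non-aromatic ring with 1 hetero atom, one six-membered aromatic ring of carbon only) in place of a group of 12 heavy atoms (9 carbon, 1 nitrogen, 2 oxygen; one five-membered non-aromatic ring with 1 hetero atom, one six-membered aromatic ring of carbon only), on an aromatic carbon, on an aromatic carbon of the shared core.

Among the measured compounds shown here, no measured pair in the set shows a step of this kind, so the direction of the change cannot be read from the data. The expectation is a step from compound 1 to compound 3 of a 1.2-fold lower number from compound 1 to compound 3 (0.09 log units; within the scatter), not beyond the scatter. For compound 3 the estimate in this assay is 40000 nM, with a range from 15000 nM to 120000 nM.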

Compound 3, concentration for total growth inhibition: 10000 nM
Compound 3: middle estimate off by 4.0-fold (0.60 log units), on the high side, and the stated range ends above it.
By their numbers in this assay, from the lowest: compound 3; then compounds 1 and 2 (each within the scatter of the next).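

In this assay, among the compounds shown here, this swap gives a 4.9-fold lower number from compound 1 to compound 3 (0.69 log units; beyond the scatter), the only step so far and one that lies beyond the scatter, so the group on the aromatic carbon of the five-membered aromatic ring with 1 nitrogen, next to the ring atom that bears a chloro group, does affect the read-out. The entering and leaving groups match in their count of 12 heavy atoms and in their ring types; the entering group carries 1 chlorine where the leaving group has a second oxygen, and it has 1 hydrogen-bond donor and 1 hydrogen-bond acceptor against 2 of each. Nothing measured here bears on what lies behind this step.

Going by these compounds, whether the step follows the arrival of the chlorine, the loss of the oxygen or the place each occupies within its group stays open, and a single pair cannot separate these readings. The same group carrying a methyl, a fluoro or an amine in place of the chlorine would test whether the step is specific to chlorine.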